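Trifluoromethyl to Methylsulfanyl: Estimating Compound 4

This account rests on a few compounds, and the source may have more. Where it says the series, first, only, none or still open, it means among the compounds named here.

Compound 1 `NC(=O)c1c(NC(=O)c2ccccc2)sc2c1CCN(C(=S)Nc1ccccc1Cl)C2` in a functional assay on HeLa cells (Homo sapiens) for antiproliferative activity, with a stated time of 24 h (on this read-out lower numbers stand for stronger inhibition and higher numbers for weaker inhibition), gives > 50000 nM, which is a limit of the assay and not a number.
Compound 2 `NC(=O)c1c(NC(=O)c2ccccc2F)sc2c1CCN(C(=S)Nc1ccccc1Cl)C2` in this assay gives 19400 nM.
Compound 3 `NC(=O)c1c(NC(=O)c2ccccc2C(F)(F)F)sc2c1CCN(C(=S)Nc1ccccc1Cl)C2` in this assay gives 46900 nM.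

Among the two numbers shown, compound 3 stands highest: the step of a 2.4-fold higher number from compound 2 to compound 3 (0.38 log units; beyond the scatter) is modest but beyond the scatter, and compound 1 sits at the limit (the limit of > 50000 nM in this assay, at which 1 of the 3 values shown sits). Compound 4 `CSc1ccccc1C(=O)Nc1sc2c(c1C(N)=O)CCN(C(=S)Nc1ccccc1Cl)C2` differs from compound 3 by methylsulfanyl in place of trifluoromethyl on an aromatic carbon.

For the measured compounds named here, no measured step swaps trifluoromethyl for methylsulfanyl, so the three steps at this position are the only guide. They show that changing the group here moves the read-out only modestly: an at least 2.5-fold lower number from compound 1 to compound 2 (0.41 log units; beyond the scatter), an at least 1.0-fold lower number from compound 1 to compound 3 (0.02 log units; that floor lies within the scatter) and a 2.4-fold higher number from compound 2 to compound 3 (0.38 log units; beyond the scatter). On that basis compound 4 is expected to land within the same narrow span, with no step beyond the scatter firmly expected, and the step of a 1.6-fold lower number from compound 3 to compound 4 (0.19 log units; within the scatter) is the estimate. Compound 4 is therefore estimated at 30000 nM, between 8000 nM and 100000 nM, with a real chance that only a limit is reported.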

Compound 4, half-maximal inhibitory concentration: 34700 nM
The estimate for compound 4 lay 1.2-fold (0.06 log units) below the measured number; the measured number falls inside the stated range.
By their numbers in this assay, from the lowest: compounds 2, 4 and 3 (each within the scatter of the next, the first and the last beyond it). At a limit, above all of these: compound 1.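

In this assay, replacing trifluoromethyl with methylsulfanyl at this position gives a step within the scatter (a 1.4-fold lower number from compound 3 to compound 4 (0.13 log units; within the scatter)), so a sulfur-bearing group fits the same range of numbers as the fluorine-bearing ones. The step from fluoro is also within the scatter (a 1.8-fold higher number from compound 2 to compound 4 (0.25 log units; within the scatter)), so compound 4 cannot be told apart from either compound 2 or compound 3, even though those two differ beyond the scatter. Compound 1 stands at a limit of the assay and not a number, so the step from hydrogen (an at least 1.4-fold lower number from compound 1 to compound 4 (0.15 log units; that floor lies within the scatter)) gives only a floor and shows no firm gain: the limit of > 50000 nM in this assay, at which 1 of the 4 values shown sits.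

As far as these compounds go, whether an amine, a carboxylic acid or a longer chain such as ethylsulfanyl would shift the number beyond the scatter remains open. So does whether any group here can bring it clearly lower than fluoro does in compound 2.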